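The source may report more compounds than this note shows. Statements on the series, on what has been measured and on what is new or still open speak of the compounds shown alone.

Compound 1 `Cc1ccc(S(=O)(=O)Oc2ccc3c(c2C)[C@H](Cn2cc(-c4ccc(Br)cc4)nn2)[C@@]24CC(=O)[C@@](C)(CC[C@@H]32)C4)cc1`: > 20000 nM
Compound 2 `C=C1C[C@]23C[C@@]1(O)CC[C@@H]2c1cccc(C)c1[C@@H]3Cn1cc(-c2ccccn2)nn1`: > 20000 nM
Compound 3 `C=C1C(=O)[C@]23C[C@@]1(O)CC[C@H]2c1ccc(O)c(C)c1[C@@H]3Cn1cc(-c2ccc(Cl)cc2)nn1`: 2470 nM

All three compounds were tested in a functional assay on MCF7 cells (Homo sapiens) for cytotoxicity, read by MTT assay, with a stated time of 4 days; a higher number here means a weaker inhibitor, a lower number a stronger inhibitor. Compound 1 did not reach a measurable number; its value is a limit of the assay. Compound 2 also returned only a limit. For the measured compounds named here, compound 3 is the one compound that gives a number, 2470 nM. Two of the three results therefore sit at the limit of > 20000 nM in this assay, at which 2 of the 3 values shown sit, and compound 1 is one of them, so it stands at the edge of what this assay can report rather than at any point inside the measured range.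

Compound 4 `Cc1ccc(S(=O)(=O)Oc2ccc3c(c2C)[C@H](Cn2cc(-c4ccccn4)nn2)[C@@]24CC(=O)[C@@](C)(CC[C@@H]32)C4)cc1` has not yet been measured. It is built on the same core as compound 1, with one change: pyridin-2-yl in place of 4-bromophenyl on an aromatic carbon. Going by the values given here, no step between two measured compounds is available to show how large a change of this kind usually is in this assay.

The expectation is that the step from compound 1 to compound 4, a step that the limit leaves unreadable from compound 1 to compound 4, is none beyond the usual scatter, with compound 4 most likely staying at the limit. Compound 4 is expected to give about 30000 nM, in a range from 8000 nM to 100000 nM.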

Compound 4, half-maximal inhibitory concentration: > 20000 nM
Compound 4: no number, only a limit; the forecaster's own chance of this, stated with the estimate: 80%; the middle value lies beyond the limit too.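

Compound 1 and compound 4 each give only a limit in this assay, not a number, so no step can be read between them: the limit of > 20000 nM in this assay, at which 3 of the 4 values shown sit.

The compounds shown leave open whether pyridin-2-yl in place of 4-bromophenyl on this shared core changes the cytotoxicity at all.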